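The source may report more compounds than this note shows. Statements on the series, on what has been measured and on what is new or still open speak of the compounds shown alone.

Measured compounds:
compound 1, `c1ccc(C(c2ccccc2)n2ccnn2)cc1`: 4580 nM
compound 2, `CCCCCCCc1cn(C(c2ccccc2)c2ccccc2)nn1`: 19400 nM
compound 3, `N#Cc1ccc(Cn2ccnn2)cc1`: 100 nM

The three measured compounds were tested in an assay on isolated protein for inhibition of Aromatase (Homo sapiens), read by fluorescence and colorimetric assay, with a stated time of 30 min; on this read-out higher numbers stand for weaker inhibition and lower numbers for stronger inhibition. In this assay compound 1 gives 4580 nM, compound 2 gives 19400 nM, and compound 3 gives 100 nM, the lowest number of the three. Compound 1 and compound 2 differ in one place, (heptyl in place of hydrogen on an aromatic carbon), and that change produced a 4.2-fold higher number from compound 1 to compound 2 (0.63 log units; beyond the scatter). How the core of compound 3 differs from the core of compound 1 is not broken down here.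

Compound 4, `CCCCCCCc1cn(Cc2ccc(C#N)cc2)nn1`, has not yet been measured. It differs from compound 3 by heptyl in place of hydrogen on an aromatic carbon. Among the measured compounds shown here, this is the same kind of change as the one from compound 1 to compound 2: in the first case the place is two ring bonds from the ring atom that bears a large group, in the second it is two ring bonds from the ring atom that bears a group of 9 heavy atoms. On the strength of the earlier step, compound 4 is expected to give a higher number than compound 3, with an estimated step of a 4.0-fold higher number from compound 3 to compound 4 (0.60 log units; beyond the scatter) in this assay, because the same kind of change gave a 4.2-fold higher number from compound 1 to compound 2 (0.63 log units; beyond the scatter). For the measured compounds named here, with only one such pair to rest on, the uncertainty is wide. The estimate for compound 4 is 400 nM, expected to lie between 150 nM and 1500 nM.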

Compound 4, half-maximal inhibitory concentration: 3070 nM
For compound 4 the middle estimate is 7.7-fold (0.89 log units) below the measured one, outside the stated range (above it).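

In this assay, the same replacement of hydrogen by heptyl on an aromatic carbon gave a 31-fold higher number from compound 3 to compound 4 (1.49 log units; beyond the scatter), so the direction of the earlier step carried over to the second core but its size did not: the same change on two cores in this assay, a 4.2-fold higher number (0.63 log units; beyond the scatter) from compound 1 to compound 2 and a 31-fold higher number (1.49 log units; beyond the scatter) from compound 3 to compound 4, 7.2-fold (0.86 log units) apart, beyond the scatter of two such steps. On the two cores shown, the heptyl group goes with weaker inhibition and no pair goes against that direction, but a step measured on one core gave only the sign of the step on the other, not a reliable size. With just two pairs, this does not show which feature of the core of compound 1 or the core of compound 3 goes with the larger or smaller step, nor what size the step would take on a further core.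

The compounds shown leave open how the step depends on chain length, since a shorter chain such as methyl or propyl on the same aromatic carbon could show whether the number rises gradually or only with a chain as long as heptyl. They also leave open whether a chain ending in an amine or a carboxylic acid would give a step of similar size on these two cores.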